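A few compounds are considered here, and "the series" means these few. Any claim that something is new, unique, unknown or untested is made for them only; others in the source may bear on it.

Compound 1 `CC(=O)OC/C(=C/c1ccccc1Br)C(=O)c1ccccc1`: 18000 nM
Compound 2 `CC(=O)OC/C(=C/c1ccccc1[N+](=O)[O-])C(=O)c1ccccc1`: 52000 nM

In a functional assay on T47D cells (Homo sapiens) for inhibition, read by sulforhodamine B assay, with a stated time of 48 h (a lower number here means a stronger inhibitor of growth, a higher number a weaker inhibitor of growth), compound 2 gives 52000 nM, the highest of the two numbers; the nearest is compound 1 at 18000 nM, and the change between them is a 2.9-fold higher number from compound 1 to compound 2 (0.46 log units; beyond the scatter). Compound 3 `O=C(OC/C(=C/c1ccccc1[N+](=O)[O-])C(=O)c1ccccc1)c1ccccc1` keeps the nitro group of compound 2 and differs by phenyl in place of methyl on a carbonyl carbon. Among the measured compounds shown here, the only measured step concerns a group on the aromatic ring, not the ester, so it offers no direct guide. The step from compound 2 to compound 3 is therefore expected to stay within the scatter, a 1.0-fold lower number from compound 2 to compound 3 (0.02 log units; within the scatter). Compound 3 is estimated at 50000 nM, with a range from 15000 nM to 150000 nM.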

Compound 3, concentration for 50% growth inhibition: 18000 nM
Beside the measured number, compound 3's estimate is 2.8-fold (0.44 log units) above it, within the range that was stated.
By their numbers in this assay, from the lowest: compounds 1 and 3 (each within the scatter of the next); then compound 2.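

In this assay, the ester end of the molecule also affects the number: going from acetoxy to benzoyloxy gives a 2.9-fold lower number from compound 2 to compound 3 (0.46 log units; beyond the scatter) and so a stronger inhibitor of growth. Until now, only a change on the aromatic ring had been seen to shift the number, and this step shows that phenyl is better than methyl on this carbonyl carbon, at least with the nitro group present. No measurement here explains why this change helps.

As far as these compounds go, it remains open whether the gain needs an aromatic ring, which a cyclohexyl group or a longer chain on the same carbonyl carbon would test. It is also unclear whether benzoyloxy would give the same gain with bromo in place of nitro.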